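The compounds below may be only part of what the source reports. "The series", "measured", "known", "first", "only" and "open" are said of these compounds alone.

Compound 1, `Nc1cc(-c2ccccc2)ccc1Cn1cncc1CNc1ccc(Cl)c(-c2ccccc2)c1`: in a toxicity assay on NIH3T3 cells (Mus musculus) for cytotoxicity, read by resazurin assay (a lower number here means that less compound is needed, a higher number that more compound is needed for the effect), compound 1 gives > 1000 nM, a limit of the assay rather than a number.
Compound 2, `COC(=O)c1ccc(NCc2cncn2Cc2cccc(Cl)c2)cc1-c1ccccc1`: compound 2 gives > 10000 nM, also a limit.
Compound 3, `CC(C)c1cccc(NCc2cncn2Cc2ccccc2)c1`: compound 3 gives > 1000 nM, again a limit.

Within the data shown here, all three readings in this assay are limits, so no compound shows measurable cytotoxicity here. Compound 2 stands at the limit of > 10000 nM in this assay, at which 1 of the 3 values shown sits. Compound 1 sits at the limit of > 1000 nM in this assay, at which 2 of the 3 values shown sit. Compound 3 sits at that same limit.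

Compound 4, `COC(=O)c1ccc(NCc2cncn2Cc2ccccc2Br)cc1-c1ccccc1`, has not yet been measured. It differs from compound 2 in one place: 2-bromophenyl in place of 3-chlorophenyl on a saturated chain carbon bound to an aromatic nitrogen. No measured pair shares this change, so nothing can be read directly from the numbers shown. With every measured compound at a limit, no shift beyond the usual scatter is expected in either direction. The expected step is a number no higher from compound 2 to compound 4 (the limit leaves the size open). Compound 4 is estimated at 10000 nM, with a range from 3000 nM to 30000 nM, and most likely only a limit will again be reported.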

Compound 4, half-maximal effective concentration: 10000 nM
Compound 4: middle estimate and measured number agree at the digits printed; low and high end bracket the measured number.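

Replacing 3-chlorophenyl with 2-bromophenyl on a saturated chain carbon bound to an aromatic nitrogen gives a number no higher from compound 2 to compound 4 (the limit leaves the size open). Among these compounds, compound 4, at 10000 nM, is the first compound in this assay to give a true number rather than a limit. Compound 2 remains a limit, so the size of this change cannot be read: the limit of > 10000 nM in this assay, at which 1 of the 4 values shown sits.

The swap changes the halogen and the name of its ring position together, so the compounds shown cannot separate the two. From the compounds shown here alone, how a nitrile in place of the bromine would read in this assay also stays open.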